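This account rests on a few compounds, and the source may have more. Where it says the series, first, only, none or still open, it means among the compounds named here.

In a functional assay on DU-145 cells (Homo sapiens) for inhibition, read by trypan blue exclusion, with a stated time of 72 h (a lower number here means a stronger inhibitor, a higher number a weaker inhibitor), compound 1 `Cn1c(=O)c(S(=O)(=O)c2ccc(F)cc2F)cc2cnc(Nc3ccc4[nH]c(C(=O)O)cc4c3)nc21` gives 10000 nM, the highest of the three numbers measured, so it is the weakest inhibitor of the set. Going by the values given here, compound 2 `Cn1c(=O)c(S(=O)(=O)c2ccc(F)cc2)cc2cnc(Nc3ccc4[nH]ccc4c3)nc21` gives 300 nM and compound 3 `Cn1c(=O)c(S(=O)(=O)Nc2ccc(F)cc2)cc2cnc(Nc3ccc4[nH]ccc4c3)nc21` gives 5000 nM; the only single-point step measured, a 17-fold higher number from compound 2 to compound 3 (1.22 log units; beyond the scatter), concerns the group on the sulfonyl sulfur, a part of the molecule that is not altered here. Compound 4 `Cn1c(=O)c(S(=O)(=O)c2ccc(F)cc2F)cc2cnc(NCc3ccc4[nH]ccc4c3)nc21` differs from compound 1 by (1H-indol-5-yl)methyl in place of 2-carboxy-1H-indol-5-yl on a nitrogen on an aromatic ring. Among the compounds with values here, no measured step covers this change. Compounds 1 and 2 differ in two places at once, one of them the 2-carboxy group, and their values show that the compound without that group sits far lower. That is the only hint on offer, and it does not separate the loss of the carboxy group from the added methylene. Compound 4 is therefore expected to land lower than compound 1 by a 5.0-fold lower number from compound 1 to compound 4 (0.70 log units; beyond the scatter), with wide uncertainty, at an estimated 2000 nM in a range from 300 nM to 10000 nM.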

Compound 4, half-maximal inhibitory concentration: 100000 nM
Estimate against measurement, compound 4: 50-fold (1.70 log units) below; the measured number lies above the stated range.
By their numbers in this assay, from the lowest: compound 2; then compounds 3 and 1 (each within the scatter of the next); then compound 4.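

In this assay, putting (1H-indol-5-yl)methyl in place of 2-carboxy-1H-indol-5-yl on the nitrogen gives a 10-fold higher number from compound 1 to compound 4 (1.00 log units; beyond the scatter), so the change moves the number up, towards a weaker inhibitor. This shows that, with the other parts of compound 1 held fixed, removing the carboxy group and adding a methylene at this position does not improve inhibition, and that the group on this nitrogen can shift the number well beyond the scatter. Nothing available explains the size of this step.

The two changes come as one step, so the share of the carboxy group and the share of the methylene cannot be told apart. Going by these compounds, a plain 1H-indol-5-yl on this nitrogen would separate them, while a methyl ester or a primary amide in place of the carboxylic acid remains open.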